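A few compounds are considered here, and "the series" means these few. Any claim that something is new, unique, unknown or untested is made for them only; others in the source may bear on it.

Measured in a functional assay on MDA-MB-231 cells (Homo sapiens) for cytotoxicity, read by MTT assay, with a stated time of 24 h; a lower number here means a stronger inhibitor, a higher number a weaker inhibitor:
- Compound 1 `COc1ccc2c(c1)cc(-c1cc(OC)c(OC)c(OC)c1)n2Cc1ccccc1`: > 30000 nM
- Compound 2 `COc1ccc2c(c1)c(Cc1ccccc1)c(-c1cc(OC)c(OC)c(OC)c1)n2Cc1ccccc1`: > 30000 nM

Compound 1 gives only a limit, > 30000 nM, and not a number. Compound 2 also gives only a limit. Going by the values given here, the series so far reads (the limit of > 30000 nM in this assay, at which 2 of the 2 values shown sit).

Compound 3 `COc1ccc2c(c1)cc(-c1cc(OC)c(OC)c(OC)c1)n2Cc1ccc(O)cc1` carries hydroxy in place of hydrogen on an aromatic carbon, which turns benzyl to 4-hydroxybenzyl. Among the compounds with values here, the one measured step, a step that the two limits leave unreadable from compound 1 to compound 2, is a different change and sets no size for this one. No clear shift is therefore expected, and any real gain would lie toward a stronger inhibitor. The expected step is a number no higher from compound 1 to compound 3 (the limit leaves the size open). For compound 3 the estimate is 30000 nM, with an expected range of 12000 nM to 60000 nM.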

Compound 3, half-maximal inhibitory concentration: 17300 nM
Compound 3: the middle estimate sits 1.7-fold (0.24 log units) above what was measured; measured number inside the range.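

Compound 3 is the only compound shown that gives a number rather than a limit in this assay. The change from benzyl to 4-hydroxybenzyl gives an at least 1.7-fold lower number from compound 1 to compound 3 (0.23 log units; that floor lies within the scatter), so a real gain is not established, though the true step may be larger. The other values are limits, and the step between them cannot be read: the limit of > 30000 nM in this assay, at which 2 of the 3 values shown sit.

As far as these compounds go, whether an amine or a carboxylic acid in place of the hydroxy would give a step beyond the scatter stays open. Also open, from the compounds shown here alone, is whether 4-hydroxybenzyl would change the reading of compound 2.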